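Cyclohexyl to 4-chlorophenyl: cytotoxicity expected to stay low

The source may hold more compounds than are shown below. What is called first, only, known or untested is meant among the compounds shown, and "the series" means these compounds.

Three amides on a shared core have been tested in a toxicity assay on THP-1 cells (Homo sapiens) for inhibition; a higher number here means that more compound is tolerated, a lower number that less compound is tolerated. Compound 1 `COc1ccc(-c2cnc(NC(=O)c3ccc(C)cc3)n2C)cc1` carries a 4-methylphenyl group on the carbonyl carbon. In this assay compound 1 reaches only the limit of > 100000 nM. Compound 2 `COc1ccc(-c2cnc(NC(=O)c3ccc(F)cc3)n2C)cc1` carries a 4-fluorophenyl group there. In this assay compound 2 also gives a limit, >= 50000 nM. Compound 3 `COc1ccc(-c2cnc(NC(=O)C3CCCCC3)n2C)cc1` carries a cyclohexyl group on the carbonyl carbon. In this assay compound 3 likewise reaches only the limit of > 100000 nM. Compound 3 thus stands at a limit, as do the other two values, and the steps a step that the two limits leave unreadable from compound 1 to compound 2, a step that the two limits leave unreadable from compound 1 to compound 3 and a step that the two limits leave unreadable from compound 2 to compound 3 have no readable size. Compound 4 `COc1ccc(-c2cnc(NC(=O)c3ccc(Cl)cc3)n2C)cc1` differs from compound 3 by 4-chlorophenyl in place of cyclohexyl on a carbonyl carbon. The steps between the aryl amides and the cyclohexyl amide bear on this change, yet the values sit at the limit of > 100000 nM in this assay, at which 2 of the 3 values shown sit, and at the limit of >= 50000 nM in this assay, at which 1 of the 3 values shown sits, so no size can be drawn from them. No step beyond the scatter is expected, and the step of a number no higher from compound 3 to compound 4 (the limit leaves the size open) is an estimate that points back toward the limit. Compound 4 is therefore expected to give about 100000 nM, within 30000 nM to 300000 nM.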

Compound 4, half-maximal cytotoxic concentration: > 100000 nM
Compound 4: no number, only a limit; the forecaster's own chance of this, stated with the estimate: 80%; the middle value sits exactly at the limit.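

In this assay compound 4 also gives only a limit. Its steps from compound 1, compound 2 and compound 3 therefore cannot be read. The compounds shown leave open at what concentration any of these four amides becomes cytotoxic, and whether the groups on the carbonyl carbon differ at all.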